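Estimated lipophilicity of compound 4 from a single amide swap

The source may hold more compounds than are shown below. What is called first, only, known or untested is meant among the compounds shown, and "the series" means these compounds.

Compound 1, `CNC(=O)c1cc(C(=O)N[C@H]2[C@@H]3COC[C@@H]32)c([C@@H](C)c2ccccc2)o1`, gives 4.1 in a physicochemical assay for lipophilicity; a lower number here means a more polar compound, a higher number a more lipophilic compound.
Compound 2, `CCNC(=O)c1cc(C(=O)NC)nn1[C@@H](C)c1ccccc1`, gives 3.7.
Compound 3, `CNC(=O)c1cc(C(=O)NC(C)CO)n([C@@H](C)c2ccccc2)n1`, gives 2.8.

Compound 1 stands highest of the three; compound 2 is nearest and compound 3 furthest, both beyond the scatter. Compound 4, `CNC(=O)c1cc(C(=O)N[C@H]2CC[C@H](O)CC2)c([C@@H](C)c2ccccc2)o1`, differs from compound 1 in one place: a group of 7 heavy atoms (6 carbon, 1 oxygen; one six-membered non-aromatic ring of carbon only) in place of a group of 6 heavy atoms (5 carbon, 1 oxygen; one three-membered non-aromatic ring of carbon only, one five-membered non-aromatic ring with 1 hetero atom), on an amide-type nitrogen. For the measured compounds named here, the only measured step that bears on this is a number 0.90 log units lower from compound 2 to compound 3 (beyond the scatter), where a hydrogen-bond donor entered on a saturated chain carbon. The present change also brings in one donor while an acceptor leaves with the departing group and one more heavy atom arrives, so a smaller downward step than that one is expected. For compound 4 the estimate in this assay is 3.5, between 3 and 4, a step of a number 0.60 log units lower from compound 1 to compound 4 (beyond the scatter).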

Compound 4, distribution coefficient: 2.8
Compound 4: middle estimate off by 0.70 log units, on the high side, outside the stated range (below it).
By their numbers in this assay, from the lowest: compounds 3 and 4 (each within the scatter of the next); then compound 2; then compound 1.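

In this assay the exchange on the amide-type nitrogen gives a number 1.30 log units lower from compound 1 to compound 4 (beyond the scatter) and so counts as a large step. At this position on the core of compound 1, the number falls even though 4-hydroxycyclohexyl is the larger group by heavy atoms and carries a hydrogen-bond donor that the departing group lacks. Nothing measured here explains the size of this step. From the compounds shown here alone, whether the hydroxyl or the six-membered carbon ring matters more remains open. A plain cyclohexyl or a 4-aminocyclohexyl on the same nitrogen would help to separate the two.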